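Swapping Bromo for Chloro on a Growth Inhibitor

This account rests on a few compounds, and the source may have more. Where it says the series, first, only, none or still open, it means among the compounds named here.

- Compound 1 `Nc1ccccc1NC(=O)c1ccc(CSc2ccc(Br)cc2)cc1`: 25.3%
- Compound 2 `CC(C)(C)c1ccc(SCc2ccc(/C=C/C(=O)Nc3ccccc3N)cc2)cc1`: 23.6%

In a functional assay on SMMC-7721 cells (Homo sapiens) for inhibition, read by CCK-8 assay, with a stated time of 72 h, tested at 8 uM (a lower number here means less inhibition of growth, a higher number more inhibition of growth at the concentration tested), compound 1 gives 25.3% and compound 2 gives 23.6%. These two values lie within the usual scatter of each other, so compound 1 stands level with compound 2 and neither can be ranked above the other.

The next compound to be tested is compound 3 `Nc1ccccc1NC(=O)c1ccc(CSc2ccc(Cl)cc2)cc1`. It differs from compound 1 in one place: chloro in place of bromo on an aromatic carbon. This puts chloro in place of bromo on an aromatic carbon, turning the 4-bromophenyl into a 4-chlorophenyl, and the rest of the structure stays the same. Going by the values given here, no measured pair here shows the effect of a single change, so the expectation starts from compound 1 at 25.3%. The expected result is a number 1.3 percentage points lower from compound 1 to compound 3 (within the scatter), which would be no step beyond the scatter. Compound 3 is estimated at 24%, with an expected range from 13% to 37%.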

Compound 3, percent growth inhibition at one concentration: 16.5%
The estimate for compound 3 lay 7.5 percentage points above the measured number, within the range that was stated.
By their numbers in this assay, from the lowest: compounds 3, 2 and 1 (each within the scatter of the next).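

In this assay, going by these compounds alone, chloro in place of bromo on the aromatic carbon gives a number 8.8 percentage points lower from compound 1 to compound 3 (within the scatter) and so offers the first comparison here that isolates a single change. At this place, para to a large group, bromo and chloro therefore cannot be told apart in this read-out, even though the printed numbers differ. The change swaps one halogen atom for another and leaves the hydrogen-bond donor and acceptor counts untouched, and no measurement here speaks to what lies behind the size of this step.

Going by these compounds, whether a different kind of group at this position, such as an amine, a carboxylic acid or a longer alkyl chain, would give a step beyond the scatter remains open. Also open, on these data alone, is whether a fluoro group here would stand level with bromo and chloro.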